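The source may hold more compounds than are shown below. What is called first, only, known or untested is meant among the compounds shown, and "the series" means these compounds.

Series notes. Three compounds are measured in an assay on isolated protein for binding affinity to Equilibrative nucleoside transporter 1 (Homo sapiens); on this read-out lower numbers stand for stronger inhibition and higher numbers for weaker inhibition. Compound 1 `CSc1ncnc2c1ncn2C1CCCCO1` gives 275000 nM; compound 2 `CCCCn1cnc2c(SCc3ccccn3)nc(N)nc21` gives 52500 nM; compound 3 `Nc1nc(SCc2ccccc2Cl)c2ncn([C@@H]3O[C@H](CO)[C@@H](O)[C@H]3O)c2n1` gives 13500 nM. On these numbers compound 3 stands lowest of the three: compound 2 is the nearest to it, with a gap beyond the scatter, and compound 1 is the furthest. No pair among these three differs in one place only, so none of the gaps between them can be tied to a single structural change.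

Compound 4 `CC(=O)c1ccccc1Sc1nc(N)nc2c1ncn2[C@@H]1O[C@H](CO)[C@@H](O)[C@H]1O` has not yet been measured in this assay. It differs from compound 3 as follows: 2-acetylphenyl in place of 2-chlorobenzyl on a sulfur. The sulfur keeps its neighbouring aromatic carbon; only the group hanging from it is exchanged. Within the data shown here, no measured pair shows what this exchange does, so the expectation rests on compound 3 alone, whose number in this assay is 13500 nM. The step expected here is a 1.5-fold higher number from compound 3 to compound 4 (0.17 log units; within the scatter), without a direction that would clearly go beyond the scatter, and the range is kept wide. Compound 4 is estimated at 20000 nM in this assay, between 5000 nM and 80000 nM.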

Compound 4, half-maximal inhibitory concentration: 447000 nM
For compound 4 the middle estimate is 22-fold (1.35 log units) below the measured one; the whole stated range lies below it.
By their numbers in this assay, from the lowest: compound 3; then compound 2; then compounds 1 and 4 (each within the scatter of the next).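

In this assay, among these compounds, the group on the sulfur is not a place where exchanges pass without effect: 2-acetylphenyl in place of 2-chlorobenzyl gives a 33-fold higher number from compound 3 to compound 4 (1.52 log units; beyond the scatter) and this is the first gap that can be tied to one structural change. The counts do little to separate the two groups, as each holds one six-membered aromatic ring of carbon only and no hydrogen-bond donors, while the entering group adds a carbonyl with its hydrogen-bond acceptor and the chlorine leaves, so the large step comes from an exchange that alters several things at once. Nothing measured here accounts for the size of this step.

Which part of the exchange carries the step remains open, as does whether a plain benzyl, a 2-chlorophenyl or a 2-acetylbenzyl on the same sulfur would stand closer to compound 3 or to compound 4. Also open, as far as these compounds go, is whether the same exchange would give a step of similar size on the core of compound 2, which carries a butyl chain where compound 3 carries its sugar.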